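The source may hold more compounds than are shown below. What is called first, only, known or untested is meant among the compounds shown, and "the series" means these compounds.

Three analogues sharing one core were examined in a functional assay on MIA PaCa-2 cells (Homo sapiens) for antiproliferative activity, read by sulforhodamine B assay, with a stated time of 48 h; on this read-out lower numbers stand for stronger inhibition and higher numbers for weaker inhibition. Compound 1 `COc1ccc(C(=O)/C=C\Nc2ccc(-c3nc4cc(OC)c(OC)c(OC)c4s3)cc2C)cc1F` gives 1800 nM, compound 2 `COc1ccc(C(=O)/C=C\Nc2ccc(-c3nc4cc(OC)c(OC)c(OC)c4s3)cc2)cc1[N+](=O)[O-]` gives 15900 nM, and compound 3 `COc1cc(OC)c2sc(-c3ccc(N/C=C\C(=O)c4ccc(OC)c(F)c4)c(C)c3)nc2c1` gives 16300 nM. Compound 3 and compound 1 differ in one place, (methoxy in place of hydrogen on an aromatic carbon), and the step of a 9.1-fold lower number from compound 3 to compound 1 (0.96 log units; beyond the scatter) was recorded. The difference between the cores of compound 2 and compound 3 is not broken down here; their values lie within the usual scatter of each other.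

Compound 4 `COc1cc(C(=O)/C=C\Nc2ccc(-c3nc4cc(OC)c(OC)c(OC)c4s3)cc2)cc([N+](=O)[O-])c1OC` has not yet been measured. It differs from compound 2 by methoxy in place of hydrogen on an aromatic carbon, the same kind of change as in the earlier pair, though here the place is on a six-membered aromatic ring of carbon only that is not part of a fused system, ortho to one methoxy group, meta to a large group and meta to a nitro group, rather than on a fused ring ortho to two methoxy groups. Because the earlier step of a 9.1-fold lower number from compound 3 to compound 1 (0.96 log units; beyond the scatter) was modest, and because the surroundings of the change differ, the step from compound 2 to compound 4 in this assay is expected to be smaller, about a 3.2-fold lower number from compound 2 to compound 4 (0.50 log units; beyond the scatter). Compound 4 is therefore estimated at 5000 nM, with a range from 1500 nM to 16000 nM.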

Compound 4, half-maximal inhibitory concentration: 15800 nM
Compound 4: the middle estimate sits 3.2-fold (0.50 log units) below what was measured, and the stated range covers the measured number.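

In this assay, methoxy in place of hydrogen on an aromatic carbon gives a 1.0-fold lower number from compound 2 to compound 4 (0.00 log units; within the scatter), so on this core the change produces no step beyond the scatter. Set beside the earlier pair, the change does not carry over with a constant size from one core to the other: the same change on two cores in this assay, a 9.1-fold lower number (0.96 log units; beyond the scatter) from compound 3 to compound 1 and a 1.0-fold lower number (0.00 log units; within the scatter) from compound 2 to compound 4, 9.0-fold (0.95 log units) apart, beyond the scatter of two such steps. These two pairs do not show whether the gap follows the core, the place of the methoxy group or the nitro group present in compound 4, since these differ together.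

The compounds shown leave open whether the methoxy step would reappear with an amine or a carboxylic acid in place of that nitro group. They also leave open how a longer chain, such as ethoxy, would behave at the same place.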